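Swapping Butoxy for Bromo: A Forecast for Compound 4

The source may report more compounds than this note shows. Statements on the series, on what has been measured and on what is new or still open speak of the compounds shown alone.

Compound 1 `Cc1cccc2oc(/C=C/[S+](C)[O-])cc(=O)c12`: 5500 nM
Compound 2 `CCCCOc1ccc2oc(/C=C/[S+](C)[O-])cc(=O)c2c1`: 4800 nM
Compound 3 `COc1cccc2c(=O)cc(/C=C/[S+](C)[O-])oc12`: 9000 nM

Of the compounds shown here, three have been tested in a functional assay on DLD-1 cells (Homo sapiens) for cytotoxicity, with a stated time of 48 h; a lower number here means a stronger inhibitor, a higher number a weaker inhibitor. Their three numbers lie within the usual scatter of one another, so compound 2 cannot be set apart from compound 1 or compound 3 in this assay. Compound 4 `C[S+]([O-])/C=C/c1cc(=O)c2cc(Br)ccc2o1` has not yet been measured; it differs from compound 2 by bromo in place of butoxy on an aromatic carbon. Among the compounds with values here, no single-point step between measured compounds is available, so there is no direct guide to how such a change acts here. Given how little the numbers of compound 1, compound 2 and compound 3 spread in this assay, the change is expected to produce no step beyond the scatter. The step of a 1.0-fold higher number from compound 2 to compound 4 (0.02 log units; within the scatter) is accordingly expected to be small. Compound 4 is estimated at 5000 nM, with a likely range from 2000 nM to 12000 nM.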

Compound 4, half-maximal inhibitory concentration: 4500 nM
Beside the measured number, compound 4's estimate is 1.1-fold (0.05 log units) above it, within the range that was stated.
By their numbers in this assay, from the lowest: compounds 4, 2, 1 and 3 (each within the scatter of the next).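

In this assay, within the data shown here, bromo in place of butoxy gives a 1.1-fold lower number from compound 2 to compound 4 (0.03 log units; within the scatter), the only step here between compounds that differ in one place. Among these compounds, at this aromatic carbon, then, the butoxy chain and its oxygen can give way to a single bromine without a step beyond the scatter, which the earlier compounds could not show. Nothing available explains this result. As far as these compounds go, whether an amine or a carboxylic acid on this carbon would give a step beyond the scatter stays open. So does whether a longer chain would.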